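This account rests on a few compounds, and the source may have more. Where it says the series, first, only, none or still open, it means among the compounds named here.

Measured compounds:
- Compound 1, `COc1cccc(NC(=O)Oc2cc(=O)n(CCCO)c3c2CC(CC=C(C)C)C(C)(C)C3)c1`, gives 16.2% in a functional assay on PANC-1 cells (Homo sapiens) for inhibition, read by MTT assay, with a stated time of 24 h, tested at 10 uM; on this read-out lower numbers stand for less inhibition and higher numbers for more inhibition at the one concentration tested (going by the name of the read-out).
- Compound 2, `COc1ccccc1NC(=O)Oc1cc(=O)n(CCCO)c2c1CC(CC=C(C)C)C(C)(C)C2`, gives 71.1% in this assay.
- Compound 3, `COc1cccc(NC(=O)Oc2cc(=O)n(CCCO)c3c2CC(C/C=C(\C)CCC=C(C)C)C(C)(C)C3)c1`, gives 47% in this assay.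

The change 2-methoxyphenyl in place of 3-methoxyphenyl on an amide-type nitrogen gave the step of a number 54.9 percentage points higher from compound 1 to compound 2 (beyond the scatter). The cores of compound 1 and compound 3 differ by 3-methylbut-2-en-1-yl in place of hydrogen on a saturated chain carbon bound to a double-bonded chain carbon, which gave a number 30.8 percentage points higher from compound 1 to compound 3 (beyond the scatter).

Compound 4, `COc1ccccc1NC(=O)Oc1cc(=O)n(CCCO)c2c1CC(C/C=C(\C)CCC=C(C)C)C(C)(C)C2`, is not yet measured. It differs from compound 3 by 2-methoxyphenyl in place of 3-methoxyphenyl on an amide-type nitrogen, the same change as from compound 1 to compound 2, at the same place. Set beside a number 54.9 percentage points higher from compound 1 to compound 2 (beyond the scatter), the expected step is a number 38 percentage points higher from compound 3 to compound 4 (beyond the scatter); it is estimated smaller than the earlier one because compound 3 already stands at 47% and the number in this assay has less room left to go higher. Compound 4 is expected to give about 85% in this assay, within 65% to 98%.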

Compound 4, a percentage reported as inhibition, at one concentration (the size of the read-out at that concentration, not a potency): 53%
Beside the measured number, compound 4's estimate is 32 percentage points above it; the measured number lies below the stated range.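

In this assay 2-methoxyphenyl in place of 3-methoxyphenyl on an amide-type nitrogen gives a number 6 percentage points higher from compound 3 to compound 4 (within the scatter) and so the step does not carry over in size from one core to the other: the same change on two cores in this assay, a number 54.9 percentage points higher (beyond the scatter) from compound 1 to compound 2 and a number 6 percentage points higher (within the scatter) from compound 3 to compound 4, 48.9 percentage points apart, beyond the scatter of two such steps
Read the other way, 3-methylbut-2-en-1-yl in place of hydrogen gives a number 18.1 percentage points lower from compound 2 to compound 4 (beyond the scatter) and this step also depends on the core: the same change on two cores in this assay, a number 30.8 percentage points higher (beyond the scatter) from compound 1 to compound 3 and a number 18.1 percentage points lower (beyond the scatter) from compound 2 to compound 4, 48.9 percentage points apart, beyond the scatter of two such steps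
The two changes are therefore not additive across these four compounds, but a single set of cores tested at one concentration does not show how general this is in the series or what causes it.

Still open, on these data alone, is how the step behaves with an unsubstituted phenyl on the amide-type nitrogen. Also open, as far as these compounds go, is whether it holds with an amine in place of the chain hydroxyl.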